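From 4-nitrophenyl to 4-cyano-2-fluorophenyl on the amide

The source may hold more compounds than are shown below. What is called first, only, known or untested is meant among the compounds shown, and "the series" means these compounds.

For the measured compounds named here, in an ADME assay on MT4 cells (Homo sapiens) for cytotoxicity, read by MTT assay, with a stated time of 5 days (on this read-out lower numbers stand for higher toxicity in this test and higher numbers for lower toxicity in this test), compound 2 (`Cc1cnc(Nc2ccc(C#N)cc2)nc1OCC(=O)Nc1ccc([N+](=O)[O-])cc1`) gives 66300 nM, the lower of the two numbers measured so far. Compound 1 (`Cc1cnc(Nc2ccc(C#N)cc2)nc1OCC(=O)Nc1cccc(Cl)c1`) gives 144000 nM. Compound 3 (`Cc1cnc(Nc2ccc(C#N)cc2)nc1OCC(=O)Nc1ccc(C#N)cc1F`) keeps the shared core and carries 4-cyano-2-fluorophenyl in place of 4-nitrophenyl on an amide-type nitrogen. Going by the values given here, only one measured step bears on this place, a 2.2-fold lower number from compound 1 to compound 2 (0.34 log units; beyond the scatter), and it is modest. Neither measured compound contains the entering group, so the evidence is indirect. That single step suggests a change of similar or smaller size in this assay, with compound 2 as the lower of the two reference points and a slightly higher number as the more likely direction. The expected change is a 1.5-fold higher number from compound 2 to compound 3 (0.18 log units; within the scatter). Compound 3 is estimated at 100000 nM, with an expected range of 35000 nM to 250000 nM.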

Compound 3, half-maximal cytotoxic concentration: > 310000 nM
Compound 3 was reported as a limit (the forecaster's own chance of this, stated with the estimate: 20%); middle value at least 3.1-fold (0.49 log units) from the limit.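

The earlier compounds shown here showed this place on an amide-type nitrogen moving the number only downward, and compound 3 shows that it can also move the other way, towards lower toxicity in this test. In this assay compound 3 is reported as a limit and not as a number: the limit of > 310000 nM in this assay, at which 1 of the 3 values shown sits. On these data alone, the change to 4-cyano-2-fluorophenyl gives an at least 4.6-fold higher number from compound 2 to compound 3 (0.66 log units; beyond the scatter), and against 3-chlorophenyl it gives an at least 2.1-fold higher number from compound 1 to compound 3 (0.33 log units; beyond the scatter), so both steps are lower bounds and their true size stays unknown.

The compounds shown leave open whether the nitrile or the fluorine carries the change, which 4-cyanophenyl or 2-fluorophenyl alone would separate. They also leave open how an amine or a carboxylic acid on this phenyl ring would read.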